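A Chlorine Swap on the Aromatic Ring of Compound 3

The compounds below may be only part of what the source reports. "The series", "measured", "known", "first", "only" and "open" are said of these compounds alone.

- Compound 1 `O=C(NNc1ccc(F)cc1)c1ccccc1NS(=O)(=O)c1cnc(O)nc1O`: > 20000 nM (a limit)
- Compound 2 `CCCCOc1ccc(C(=O)NNC(=O)c2ccccc2NS(=O)(=O)c2cnc(O)nc2O)cc1`: 5010 nM
- Compound 3 `Cc1ccc(C(=O)NNC(=O)c2ccccc2NS(=O)(=O)c2cnc(O)nc2O)cc1`: 12900 nM

In a functional assay on OVCAR-3 cells (Homo sapiens) for antiproliferative activity, read by MTT assay, with a stated time of 24 h (a lower number here means a stronger inhibitor, a higher number a weaker inhibitor), compound 3 gives 12900 nM, the higher of the two actual numbers. The result for compound 1 is only a limit.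

Compound 4 `O=C(NNC(=O)c1ccccc1NS(=O)(=O)c1cnc(O)nc1O)c1ccccc1Cl` differs from compound 3 at one place: 2-chlorophenyl in place of 4-methylphenyl on a carbonyl carbon. In short, 2-chlorophenyl stands in place of 4-methylphenyl on a carbonyl carbon.

Within the data shown here, two measured steps bear on this. The modest 2.6-fold higher number from compound 2 to compound 3 (0.41 log units; beyond the scatter) swaps butoxy for methyl, while an at least 1.5-fold lower number from compound 1 to compound 3 (0.19 log units; that floor lies within the scatter) rests on a limit. Neither involves chlorine, so no step beyond the scatter is expected in this assay, and no direction is favoured. The expected step is a 1.2-fold lower number from compound 3 to compound 4 (0.07 log units; within the scatter). For compound 4 the estimate is 11000 nM, with an expected range of 5000 nM to 20000 nM.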

Compound 4, half-maximal inhibitory concentration: 18200 nM
Compound 4: middle estimate off by 1.7-fold (0.22 log units), on the low side; low and high end bracket the measured number.
By their numbers in this assay, from the lowest: compound 2; then compounds 3 and 4 (each within the scatter of the next). At a limit, above all of these: compound 1.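

Placing 2-chlorophenyl where 4-methylphenyl stood on this carbonyl carbon gives a 1.4-fold higher number from compound 3 to compound 4 (0.15 log units; within the scatter). The 4-butoxyphenyl group remains the one that stands apart, with a 3.6-fold higher number from compound 2 to compound 4 (0.56 log units; beyond the scatter). Compound 1 gives only a limit: the limit of > 20000 nM in this assay, at which 1 of the 4 values shown sits. Resting on that limit, the remaining step is an at least 1.0-fold lower number from compound 1 to compound 4 (0.04 log units; that floor lies within the scatter), so it cannot be read as a real difference.

Still open, going by these compounds, is whether 4-chlorophenyl would behave like 2-chlorophenyl. On these data alone, it is also open whether a hexyloxy chain, an amine or a carboxylic acid on this ring would move the number further than butoxy does.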